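Furan for thiophene on two related nucleoside cores

A few compounds are considered here, and "the series" means these few. Any claim that something is new, unique, unknown or untested is made for them only; others in the source may bear on it.

Four compounds share a nucleoside scaffold and differ in two places. Compound 1 `O=c1[nH]cnc2c1c(-c1ccoc1)cn2[C@@H]1O[C@H](CO)[C@@H](O)[C@H]1O` carries a furan-3-yl group on the first core; in a functional assay on K562 cells (Homo sapiens), read by MTT assay, with a stated time of 72 h (a higher number here means a weaker inhibitor, a lower number a stronger inhibitor), compound 1 gives 12500 nM. Compound 2 `O=c1[nH]cnc2c1c(-c1ccsc1)cn2[C@@H]1O[C@H](CO)[C@@H](O)[C@H]1O` carries thiophen-3-yl on that same core. Compound 2 reaches only the limit of this assay, > 20000 nM. The step of an at least 1.6-fold lower number from compound 2 to compound 1 (0.20 log units; that floor lies within the scatter) belongs to the change (furan-3-yl in place of thiophen-3-yl on an aromatic carbon). Compound 3 `CNc1ncnc2c1c(-c1ccsc1)cn2[C@@H]1O[C@H](CO)[C@@H](O)[C@H]1O` has the thiophen-3-yl group on the second core, whose difference from the core of compound 2 is not broken down here. Compound 3 likewise stops at the limit of this assay, > 20000 nM. Compound 4 `CNc1ncnc2c1c(-c1ccoc1)cn2[C@@H]1O[C@H](CO)[C@@H](O)[C@H]1O` applies the same change to compound 3: furan-3-yl in place of thiophen-3-yl on an aromatic carbon. Because two of the three known values sit at the limit of > 20000 nM in this assay, at which 2 of the 3 values shown sit, the measured step is only a floor. For compound 4 the expected step is an at least 1.1-fold lower number from compound 3 to compound 4 (0.04 log units; that floor lies within the scatter), resting on an at least 1.6-fold lower number from compound 2 to compound 1 (0.20 log units; that floor lies within the scatter). Compound 4 is estimated at 18000 nM, between 8000 nM and 40000 nM.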

Compound 4, half-maximal inhibitory concentration: > 20000 nM
Compound 4 was reported as a limit; the forecaster's own chance of this, stated with the estimate: 55%; middle value at least 1.1-fold (0.04 log units) away from the limit.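

Compound 4, like compound 3, stops at a limit in this assay, so no step between these two compounds can be read: the limit of > 20000 nM in this assay, at which 3 of the 4 values shown sit.

The compounds shown leave open whether furan-3-yl in place of thiophen-3-yl changes the number at all on the core of compound 3.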